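The compounds below may be only part of what the source reports. "The series", "measured", "known", "first", "only" and "open" are said of these compounds alone.

Of the compounds shown here, three have so far been tested in a functional assay on THP-1 cells (Homo sapiens) for inhibition, read by sulforhodamine B assay, with a stated time of 48 h, tested at 50 uM; on this read-out lower numbers stand for less inhibition of growth and higher numbers for more inhibition of growth at the one concentration tested. Compound 1 `O=C1C(=O)N(CCCCCn2cc(COc3cc(=O)oc4ccccc34)nn2)c2ccc(F)cc21` gives 63%, compound 2 `O=C1C(=O)N(CCCCCn2cc(COc3cc(=O)oc4ccccc34)nn2)c2ccc(I)cc21` gives 45%, and compound 3 `O=C1C(=O)N(CCCn2cc(COc3cc(=O)oc4ccccc34)nn2)c2ccc(I)cc21` gives 67%. Compound 2 and compound 1 share a core and differ only by fluoro in place of iodo on an aromatic carbon; that change brought a number 18 percentage points higher from compound 2 to compound 1 (beyond the scatter). The core of compound 3 is related, but its difference from compound 2 is not broken down here. Compound 4 `O=C1C(=O)N(CCCn2cc(COc3cc(=O)oc4ccccc34)nn2)c2ccc(F)cc21`, not yet measured, differs from compound 3 by fluoro in place of iodo on an aromatic carbon, the same change as between compound 2 and compound 1. Given that this change earlier gave a number 18 percentage points higher from compound 2 to compound 1 (beyond the scatter), a step of a number 11 percentage points higher from compound 3 to compound 4 (beyond the scatter) is expected, kept somewhat smaller only because the number for compound 3, 67%, leaves less room to climb. Compound 4 is therefore estimated at 78% in this assay, likely between 65% and 90%.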

Compound 4, percent growth inhibition at one concentration: 86%
Beside the measured number, compound 4's estimate is 8 percentage points below it, and the stated range covers the measured number.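

Fluoro in place of iodo gave a number 19 percentage points higher from compound 3 to compound 4 (beyond the scatter) in this assay. Set beside the earlier case, the step kept its size on the second core: the same change on two cores in this assay, a number 18 percentage points higher (beyond the scatter) from compound 2 to compound 1 and a number 19 percentage points higher (beyond the scatter) from compound 3 to compound 4, 1 percentage points apart, within the scatter of two such steps This rests on only two pairs of compounds, each tested at a single concentration, so it does not show why fluoro gives the higher number or whether the step would hold on any other core.

The compounds shown leave open how chloro or bromo in the same place would compare with fluoro and iodo. They also leave open whether the step would persist with a chain longer than any in the compounds shown.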